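The compounds below may be only part of what the source reports. "The series", "measured", "known", "first", "only" and "open" are said of these compounds alone.

Measured in a functional assay on MDA-MB-231 cells (Homo sapiens) for cytotoxicity, read by cell counting, with a stated time of 48 h; on this read-out lower numbers stand for stronger inhibition and higher numbers for weaker inhibition:
compound 1 `Cc1ccc(-n2cc(COc3cccc4cnc(Nc5cccc(Cl)c5)nc34)nn2)c([N+](=O)[O-])c1`: > 25000 nM, a limit
compound 2 `COc1ccccc1-n1cc(COc2cccc3cnc(Nc4cccc(Cl)c4)nc23)nn1`: > 25000 nM, a limit
compound 3 `Clc1cccc(Nc2ncc3cccc(OCc4cn(Cc5c(Cl)cccc5Cl)nn4)c3n2)c1`: 21000 nM

Within the data shown here, compound 3 gives the only actual number of the three, 21000 nM. Compound 1 and compound 2 both stand at the limit of > 25000 nM in this assay, at which 2 of the 3 values shown sit.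

Compound 4 `COc1cccc(-n2cc(COc3cccc4cnc(Nc5cccc(Cl)c5)nc34)nn2)c1` carries 3-methoxyphenyl in place of 2,6-dichlorobenzyl on an aromatic nitrogen. The closest measured steps are an at least 1.1-fold lower number from compound 1 to compound 3 (0.07 log units; that floor lies within the scatter) and an at least 1.1-fold lower number from compound 2 to compound 3 (0.07 log units; that floor lies within the scatter), both with floors within the scatter, while a step that the two limits leave unreadable from compound 1 to compound 2 cannot be read. Compound 2, with 2-methoxyphenyl on that nitrogen, remains a limit at > 25000 nM. In this assay no step beyond the scatter is therefore expected, at most a slightly higher number, and a report as a limit is likely. The expected step is a 1.3-fold higher number from compound 3 to compound 4 (0.12 log units; within the scatter). For compound 4 the estimate is 28000 nM, with an expected range of 14000 nM to 50000 nM.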

Compound 4, half-maximal inhibitory concentration: 25000 nM
The estimate for compound 4 lay 1.1-fold (0.05 log units) above the measured number; the measured number falls inside the stated range.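

In this assay, with 3-methoxyphenyl in place of 2,6-dichlorobenzyl on an aromatic nitrogen, the step is a 1.2-fold higher number from compound 3 to compound 4 (0.08 log units; within the scatter), and compound 4 adds a second actual number to the series. Compound 1 and compound 2 remain limits, not numbers: the limit of > 25000 nM in this assay, at which 2 of the 4 values shown sit. With 3-methoxyphenyl in place of 2-methoxyphenyl on this nitrogen the step is a number no higher from compound 2 to compound 4 (the limit leaves the size open), and with 3-methoxyphenyl in place of 4-methyl-2-nitrophenyl it is a number no higher from compound 1 to compound 4 (the limit leaves the size open); the size of neither step can be read.

No readable step shows a group on this nitrogen moving the number beyond the scatter. From the compounds shown here alone, whether an amine, such as a morpholine, or a carboxylic acid at this position would do so remains open.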